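The source may hold more compounds than are shown below. What is called first, only, known or untested is meant among the compounds shown, and "the series" means these compounds.

Measured so far in a physicochemical assay for solubility, with a stated time of 3 days, at pH 2; on this read-out lower numbers stand for lower solubility and higher numbers for higher solubility:
- compound 1 `Cc1ccc(CN2CCCC(COc3ccc(-c4nc5cc(C(N)=O)ccc5[nH]4)cc3)C2)cc1`: "not determined" (no result reported)
- compound 2 `NC(=O)c1ccc2[nH]c(-c3ccc(OCC4CCCN(Cc5ccc(Cl)cc5)C4)cc3)nc2c1`: "not determined" (no result reported)
- compound 3 `NC(=O)c1ccc2[nH]c(-c3ccc(OCCC4CCCCN4Cc4ccccc4)cc3)nc2c1`: > 400000 nM

In this assay compound 3 gives > 400000 nM, and this is a limit of the assay and not a number. Among the compounds with values here, it is the only entry with a reading of any kind. Compound 1 and compound 2 have no reported result, so neither offers a comparison, and the series has no exact value to anchor on.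

The next compound is compound 4 `Cc1ccc(CN2CCCCC2CCOc2ccc(-c3nc4cc(C(N)=O)ccc4[nH]3)cc2)cc1`. The change from compound 3 is methyl in place of hydrogen on an aromatic carbon, taking benzyl to 4-methylbenzyl. The rest of the structure stays the same.

Within the data shown here, no measured step gauges this change, so the expectation is a cautious one. No step beyond the scatter is expected in this assay, and a fall cannot be ruled out. The estimated step is a number no higher from compound 3 to compound 4 (the limit leaves the size open). A further limit rather than a number is the likeliest report.

For compound 4 the estimated value is 400000 nM, with an expected range from 150000 nM to 500000 nM.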

Compound 4, solubility: > 400000 nM
Compound 4 ended at the assay's limit; the forecaster's own chance of this, stated with the estimate: 65%; the middle value lies on the limit itself.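

In this assay, compound 3 and compound 4 both give a limit and not a number, so no step can be read between them: the limit of > 400000 nM in this assay, at which 2 of the 4 values shown sit.

The compounds shown leave open where either compound lies beyond that limit, and so whether benzyl to 4-methylbenzyl shifts the read-out at all.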